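A Methyl Placed Differently on Two Compounds

This account rests on a few compounds, and the source may have more. Where it says the series, first, only, none or still open, it means among the compounds named here.

In an assay on isolated protein for inhibition of high affinity 3',5'-cyclic-AMP phosphodiesterase 7A (Homo sapiens), read by cAMP accumulation, with a stated time of 10 min (on this read-out lower numbers stand for stronger inhibition and higher numbers for weaker inhibition), compound 1 `COc1nc2c(c(=O)n(C)c(=O)n2C)n1CC(=O)Nc1cccc(Cl)c1` reaches only a limit, > 200000 nM. Compound 3 `COc1nc2c(c(=O)n(C)c(=O)n2C)n1CCCC(=O)Nc1ccc(C(C)C)cc1` likewise stops at a limit in this assay, > 200000 nM. Compound 2 `COc1nc2c(c(=O)n(C)c(=O)n2C)n1CCCC(=O)Nc1ccc(C(C)(C)C)cc1`, by contrast, gives a number in this assay, 19800 nM. The step of an at least 10-fold lower number from compound 3 to compound 2 (1.00 log units; beyond the scatter) accompanies (methyl in place of hydrogen on a saturated chain carbon bound to an aromatic carbon and two saturated chain carbons). Compound 4 `CCOc1nc2c(c(=O)n(C)c(=O)n2C)n1CC(=O)Nc1cccc(Cl)c1` differs from compound 1 by methyl in place of hydrogen on a saturated chain carbon bound to an oxygen on an aromatic ring, the same kind of change, though here the place is a saturated chain carbon bound to an oxygen on an aromatic ring rather than one bound to an aromatic carbon and two saturated chain carbons. The difference between the cores of compound 1 and compound 3 is not broken down here. Compound 1 sits at the limit of > 200000 nM in this assay, at which 2 of the 3 values shown sit. The writer expects a step that the limit leaves unreadable from compound 1 to compound 4 because an at least 10-fold lower number from compound 3 to compound 2 (1.00 log units; beyond the scatter) was made at a different place. For compound 4 the estimate is 250000 nM, expected between 50000 nM and 1000000 nM.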

Compound 4, half-maximal inhibitory concentration: > 200000 nM
Compound 4 ended at the assay's limit; the forecaster's own chance of this, stated with the estimate: 70%; the middle value lies beyond the limit too.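

For the compounds shown here, compound 1 and compound 4 both stop at a limit in this assay, and no step between them can be read. The compounds shown leave open whether methoxy to ethoxy changes inhibition at all.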